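Chloro for Methoxy: Expected Cell Tolerance of Compound 4

The source may hold more compounds than are shown below. What is called first, only, known or untested is meant among the compounds shown, and "the series" means these compounds.

Measured compounds:
Compound 1, `COc1ccccc1-c1cnc(NC(=O)c2ccc(F)cc2)n1C`, gives in a toxicity assay on THP-1 cells (Homo sapiens) for inhibition (a higher number here means that more compound is tolerated, a lower number that less compound is tolerated), a value that is only a limit of the assay, > 100000 nM.
Compound 2, `COc1ccccc1-c1cnc(NC(=O)c2ncc[nH]2)n1C`, gives in this assay only a limit, > 50000 nM.
Compound 3, `COc1ccc(-c2nc3ncc(-c4ccc(F)cc4)cc3[nH]2)cc1`, gives in this assay only a limit, > 100000 nM.

Compound 2 stands at the limit of > 50000 nM in this assay, at which 1 of the 3 values shown sits, while the two other measured compounds sit at the limit of > 100000 nM in this assay, at which 2 of the 3 values shown sit. Within the data shown here, the only step between measured compounds that differ in one place, a step that the two limits leave unreadable from compound 1 to compound 2, cannot be read: its two ends are limits. Compound 4, `Cn1c(-c2ccccc2Cl)cnc1NC(=O)c1ncc[nH]1`, differs from compound 2 by chloro in place of methoxy on an aromatic carbon. No measured step involves this change, and none of the three measured values is a number, so nothing shown points to a move in either direction. Compound 4 is therefore expected to behave like compound 2, and the step that the limit leaves unreadable from compound 2 to compound 4 is expected to be none beyond the scatter. Compound 4 is estimated at 80000 nM, within a range from 30000 nM to 200000 nM, most likely again reported only as a limit.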

Compound 4, half-maximal cytotoxic concentration: > 50000 nM
Compound 4 ended at the assay's limit (the forecaster's own chance of this, stated with the estimate: 80%); the middle value lies beyond the limit too.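

Compound 2 and compound 4 both end at a limit of the assay rather than at a number, so the step between them cannot be read. In this assay, the compounds shown leave open where any of them turns toxic, and whether chloro and methoxy differ at all.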